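Swapping the hydroxyphenyl for bromophenyl on the shared core

This account rests on a few compounds, and the source may have more. Where it says the series, first, only, none or still open, it means among the compounds named here.

Of the compounds shown here, three with one shared core have been tested in an ADME assay on L929 cells (Mus musculus) for cytotoxicity, read by resazurin assay, with a stated time of 72 h; on this read-out lower numbers stand for stronger inhibition and higher numbers for weaker inhibition. Compound 1 (`CCc1ccc(C(=O)/C=C/c2ccc3c(c2)B(O)OC3)cc1`) gives > 10 ug/mL, which is a limit of the assay and not a number. Compound 2 (`O=C(/C=C/c1ccc2c(c1)B(O)OC2)c1ccccc1O`) gives > 10 ug/mL, which is likewise a limit. For the measured compounds named here, compound 3 (`COCOc1ccccc1C(=O)/C=C/c1ccc2c(c1)B(O)OC2`) gives 9.02 ug/mL, the only true number so far. Compound 2 thus has no exact position on this scale.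

Compound 4 (`O=C(/C=C/c1ccc2c(c1)B(O)OC2)c1ccc(Br)cc1`) has not yet been measured. It carries 4-bromophenyl in place of 2-hydroxyphenyl on a carbonyl carbon. Going by the values given here, only one measured step bears on this change, and only in part, since it alters the same group in a different way: an at least 1.1-fold lower number from compound 2 to compound 3 (0.04 log units; that floor lies within the scatter). The remaining guide is the limit of > 10 ug/mL in this assay, at which 2 of the 3 values shown sit. Among the compounds with values here, because compound 3 gives 9.02 ug/mL and the one measured step stays within the scatter, no step beyond the scatter is expected in this assay, in either direction. The estimated step is an at least 1.1-fold lower number from compound 2 to compound 4 (0.04 log units; that floor lies within the scatter). For compound 4 the expected value is 9 ug/mL, with an estimated range from 3.5 ug/mL to 20 ug/mL.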

Compound 4, half-maximal inhibitory concentration: > 10 ug/mL
Compound 4 ended at the assay's limit (the forecaster's own chance of this, stated with the estimate: 45%); at least 1.1-fold (0.04 log units) between middle value and limit.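

Compound 4 gives > 10 ug/mL, which is a limit of the assay and not a number. For the compounds shown here, compound 1 and compound 2 also stand at limits, so no step to compound 4 from either of them can be read. The compounds shown leave open how far 4-bromophenyl in place of 2-hydroxyphenyl, or bromo in place of ethyl, moves the read-out.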